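Changing the Aryl Group on an Aromatic Nitrogen

This account rests on a few compounds, and the source may have more. Where it says the series, first, only, none or still open, it means among the compounds named here.

Compound 1 `Cc1cccc(-n2nncc2CN2C(=O)C3(C(C#N)=C(N)Oc4c3c3nc5ccccc5nc3c3ccccc43)c3ccccc32)c1`: > 50000 nM
Compound 2 `N#CC1=C(N)Oc2c(c3nc4ccccc4nc3c3ccccc23)C12C(=O)N(Cc1cnnn1-c1ccc(Br)cc1)c1ccccc12`: > 50000 nM
Compound 3 `CCc1ccccc1-n1nncc1CN1C(=O)C2(C(C#N)=C(N)Oc3c(N)cc4nc5ccccc5nc4c32)c2ccccc21`: 10300 nM

The series was tested in a functional assay on HCT-116 cells (Homo sapiens) for antiproliferative activity, read by MTT assay, with a stated time of 48 h; a lower number here means a stronger inhibitor, a higher number a weaker inhibitor. Compound 1 reaches only a limit of the assay at > 50000 nM. Compound 2 likewise reaches only a limit at > 50000 nM. Among the measured compounds shown here, compound 3 is the one member with a measured number, at 10300 nM, so it stands alone as the sole readable point among the three values.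

For the measured compounds named here, the one step between measured compounds, a step that the two limits leave unreadable from compound 1 to compound 2, also concerns the aryl group on the aromatic nitrogen, but its size cannot be read because of the limit of > 50000 nM in this assay, at which 2 of the 3 values shown sit.

Compound 4 `N#CC1=C(N)Oc2c(N)cc3nc4ccccc4nc3c2C12C(=O)N(Cc1cnnn1-c1cc(Cl)ccc1Cl)c1ccccc12` differs from compound 3 by 2,5-dichlorophenyl in place of 2-ethylphenyl on an aromatic nitrogen. Going by the values given here, the only related step therefore offers no readable size, and no other measured step bears on this change. With no evidence for a shift in either direction, the step is expected to stay within the usual scatter, a 1.0-fold lower number from compound 3 to compound 4 (0.01 log units; within the scatter). Compound 4 is accordingly expected to give about 10000 nM, with a range from 3000 nM to 50000 nM, and a real chance that only a limit is returned.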

Compound 4, half-maximal inhibitory concentration: > 50000 nM
Compound 4 was reported as a limit; the forecaster's own chance of this, stated with the estimate: 25%; middle value at least 5.0-fold (0.69 log units) from the limit.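

In this assay, among the compounds shown here, the change to 2,5-dichlorophenyl in place of 2-ethylphenyl gives an at least 4.8-fold higher number from compound 3 to compound 4 (0.68 log units; beyond the scatter) and so, unlike the one earlier step on this aromatic nitrogen, which cannot be read, shows that the aryl group here can move the result beyond the scatter. The two groups match in heavy-atom count, in carrying one six-membered aromatic ring of carbon only and in having no hydrogen-bond donors or acceptors, so these counts do not separate them, and what differs is the pair of chlorine atoms set against the ethyl chain. The step gives only a minimum, and its full size stays unknown because compound 4 returned only a limit: the limit of > 50000 nM in this assay, at which 3 of the 4 values shown sit.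

Compound 3 remains the only measured number, so the compounds shown do not tell whether any aryl group on this nitrogen could give a lower number than compound 3 does. As far as these compounds go, it also stays open whether a single chlorine, a methoxy group or an amine on the phenyl ring would keep a measurable value, and which of the two chlorine atoms of compound 4 matters more.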